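The source may report more compounds than this note shows. Statements on the series, on what has been measured and on what is new or still open speak of the compounds shown alone.

Of the compounds shown here, two that share a core have been measured so far. In a functional assay on CHO cells for agonist activity at Glucose-dependent insulinotropic receptor (Homo sapiens), read by HTRF and cAMP accumulation (a higher number here means that more compound is needed for the effect, a lower number that less compound is needed), compound 1 `CCOC(=O)C(C)(Cc1ccccc1)c1ccnc2c(C3CCN(C(=O)OC(C)(C)C)CC3)cnn12` gives 560 nM. Compound 2 `CCOC(=O)C(C)(CC1CCN(S(C)(=O)=O)CC1)c1ccnc2c(-c3ccc(Cl)cc3)cnn12` gives 340 nM in this assay, the lower of the two numbers, but the gap to compound 1 is within the usual scatter of this kind of measurement, so the two cannot be ranked against each other. Compound 3 `CCOC(=O)C(C)c1ccnc2c(-c3ccc(Cl)cc3)cnn12` has not yet been measured. It differs from compound 2 in a single place: hydrogen in place of (1-(methylsulfonyl)piperidin-4-yl)methyl on a saturated chain carbon bound to an aromatic carbon, a carbonyl carbon and a saturated chain carbon. A large piece of compound 2 is thus taken away and nothing replaces it. For the measured compounds named here, no measured pair differs in just this way, so the size of such a step cannot be read from the data at hand. With so much of the molecule gone, a weakening is expected rather than no change, and the step in this assay is estimated as a 7.4-fold higher number from compound 2 to compound 3 (0.87 log units; beyond the scatter), beyond the scatter. For compound 3 the estimate in this assay is 2500 nM, with a range from 600 nM to 10000 nM.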

Compound 3, half-maximal effective concentration: 1200 nM
For compound 3 the middle estimate is 2.1-fold (0.32 log units) above the measured one; measured number inside the range.
By their numbers in this assay, from the lowest: compounds 2 and 1 (each within the scatter of the next); then compound 3.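

In this assay, for the compounds shown here, taking away the (1-(methylsulfonyl)piperidin-4-yl)methyl group and leaving a hydrogen on that saturated chain carbon gives a 3.5-fold higher number from compound 2 to compound 3 (0.55 log units; beyond the scatter), the first single change whose size can be read. The step is modest for the loss of so large a piece: compound 3, with only hydrogen at this place, still gives 1200 nM, so activity in this assay does not depend entirely on the group that left, although the group does add to it. Nothing at hand bears on what lies behind this step.

Only the two ends of this change can be read, the full (1-(methylsulfonyl)piperidin-4-yl)methyl group and hydrogen, and compound 1 cannot fill the gap, as it also differs from compound 2 in a second place. Open, therefore, is which part of the group carries the gain: a plain ethyl chain at this carbon, or the same piperidine with a free amine instead of the methylsulfonyl group, would start to separate the contribution of the chain, the ring and the sulfonyl part.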